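The compounds below may be only part of what the source reports. "The series", "measured", "known", "first", "only" and "open" are said of these compounds alone.

Measured compounds:
- compound 1 `CCC(=O)N1CC2CNCC2C1`, 12 nM
- compound 2 `O=C(C1CC1)[C@H]1C[C@H]2CNC[C@H]2C1`, 0.5 nM

Both compounds share a bicyclic secondary-amine core carrying an acyl group. In an assay on SHEP1 cells for displacement of a labelled ligand from Neuronal acetylcholine receptor; alpha4/beta2 (Homo sapiens), read by scintillation counting, with a stated time of 2 h (a lower number here means a stronger inhibitor, a higher number a weaker inhibitor), compound 1 gives 12 nM, while compound 2 gives 0.5 nM. Among the compounds with values here, compound 2 therefore stands at the lowest number of the two, and its gap to compound 1 lies beyond the usual scatter; no single-point step between the two is on record, so the gap is taken only as what the two values show.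

Compound 3 `O=C(c1ccco1)[C@H]1C[C@H]2CNC[C@H]2C1` is not yet measured in this assay. It differs from compound 2 by furan-2-yl in place of cyclopropyl on a carbonyl carbon. The carbonyl and the core are unchanged. With no measured step of this kind in the series, the direction is open; a moderate shift either way is plausible, and a loss of some size is thought a little more likely than a gain given how low compound 2 already sits at 0.5 nM.

The step from compound 2 to compound 3 is estimated at a 4.0-fold higher number from compound 2 to compound 3 (0.60 log units; beyond the scatter), expected to sit near the edge of the scatter. Compound 3 is accordingly expected to give 2 nM in this assay, within a range from 0.3 nM to 15 nM.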

Compound 3, inhibition constant: 13 nM
Estimate against measurement, compound 3: 6.5-fold (0.81 log units) below, and the stated range covers the measured number.
By their numbers in this assay, from the lowest: compound 2; then compounds 1 and 3 (each within the scatter of the next).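

Working notes on the carbonyl substituent: in this assay, furan-2-yl in place of cyclopropyl on a carbonyl carbon gives a 26-fold higher number from compound 2 to compound 3 (1.41 log units; beyond the scatter), with the carbonyl and the shared core unchanged. Within the data shown here, this is the first single-place step, and it shows that the result at this position depends strongly on the group carried by the carbonyl, with cyclopropyl clearly ahead of furan-2-yl in this pair. The change replaces a three-membered non-aromatic carbon ring with a five-membered aromatic ring holding one hetero atom, and no measurement on record bears on why the number moves.

As far as these compounds go, a single step cannot separate ring size, aromatic character and the added hydrogen-bond acceptor, so which of these differences goes with the step remains open. The compounds shown also leave open how cyclobutyl, phenyl or thiophen-2-yl on the same carbonyl carbon would stand in this assay, and whether any group there gives a lower number than cyclopropyl.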